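The source may hold more compounds than are shown below. What is called first, only, known or untested is meant among the compounds shown, and "the series" means these compounds.

Measured compounds:
Compound 1, `CCOC(=O)c1sc(-c2cccc(NC(=O)c3ccc(F)cc3)c2)nc1Nc1ccc(N2CCN(C)CC2)cc1`, gives 3.53% in a functional assay on Ramos cells (Homo sapiens) for antiproliferative activity, read by CCK-8 assay, with a stated time of 72 h, tested at 40 uM; on this read-out lower numbers stand for less inhibition and higher numbers for more inhibition at the one concentration tested (going by the name of the read-out).
Compound 2, `CCOC(=O)c1sc(-c2cccc(NC(=O)c3ccc(C#N)cc3)c2)nc1Nc1ccc(N2CCN(C)CC2)cc1`, gives 97.5% in this assay.

Compound 2 stands highest of the two numbers; its nearest neighbour is compound 1, and the step of a number 94 percentage points higher from compound 1 to compound 2 (beyond the scatter) lies beyond the scatter. Compound 3, `CCOC(=O)c1sc(-c2cccc(NC(=O)c3ccc(F)c(Cl)c3)c2)nc1Nc1ccc(N2CCN(C)CC2)cc1`, has not been measured yet. It differs from compound 2 in one place: 3-chloro-4-fluorophenyl in place of 4-cyanophenyl on a carbonyl carbon. Among the measured compounds shown here, the only measured step that bears on this change is a number 94 percentage points higher from compound 1 to compound 2 (beyond the scatter), which shows that cyano in place of fluoro on an aromatic carbon raised the inhibition very strongly. For the measured compounds named here, compound 3 reverses that swap and additionally carries chloro, for which no step is known. A large fall in this assay is therefore expected, estimated as a number 72.5 percentage points lower from compound 2 to compound 3 (beyond the scatter), though the added chloro leaves the size uncertain. For compound 3 the inhibition is expected to be about 25%, within 2% to 75%.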

Compound 3, a percentage reported as inhibition, at one concentration (the size of the read-out at that concentration, not a potency): 72.5%
For compound 3 the middle estimate is 47.5 percentage points below the measured one; measured number inside the range.
By their numbers in this assay, from the lowest: compound 1; then compound 3; then compound 2.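

In this assay, among the compounds shown here, chloro in place of hydrogen on an aromatic carbon gives a number 69 percentage points higher from compound 1 to compound 3 (beyond the scatter), so the nitrile is not the only change on this ring that lifts the inhibition far above that of compound 1. Moving the other way, 3-chloro-4-fluorophenyl in place of 4-cyanophenyl on a carbonyl carbon gives a number 25 percentage points lower from compound 2 to compound 3 (beyond the scatter), a modest step next to the large one, which shows that a ring keeping its fluoro can still reach high inhibition. What the compounds shown leave open is whether chloro would do the same without the fluoro, and how a carboxylic acid or a morpholine on this ring would read at the one concentration tested. Nothing measured here accounts for either step.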